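Swapping chloro for hydroxy beside the methoxy group

This account rests on a few compounds, and the source may have more. Where it says the series, first, only, none or still open, it means among the compounds named here.

Measured so far in a functional assay on MDA-MB-468 cells (Homo sapiens) for antiproliferative activity; on this read-out lower numbers stand for stronger inhibition of growth and higher numbers for weaker inhibition of growth:
Compound 1 `Cc1cc(-c2nc3ccccc3s2)ccc1N` gives < 0.1 nM in this assay, and that value is a limit of the assay rather than a number.
Compound 2 `COc1ccc(-c2nc3cc(F)ccc3s2)cc1` gives 330 nM.
Compound 3 `COc1ccc(-c2nc3cc(F)ccc3s2)cc1Cl` gives 480 nM.

Within the data shown here, compound 3 and compound 2 share the same core and differ only by a chloro in place of hydrogen on an aromatic carbon; the single measured step, a 1.5-fold higher number from compound 2 to compound 3 (0.16 log units; within the scatter), stays within the usual scatter, so the two values cannot be told apart. Among the measured compounds shown here, compound 1 carries different groups and gives only a limit, so it offers no step that can be compared.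

The unmeasured compound 4 `COc1ccc(-c2nc3cc(F)ccc3s2)cc1O` arises from compound 3 by hydroxy in place of chloro on an aromatic carbon. For the measured compounds named here, no measured pair shows a hydroxy entering or a chloro leaving, so the one step on hand, a 1.5-fold higher number from compound 2 to compound 3 (0.16 log units; within the scatter), bears on this change only loosely: it shows that exchanging a small group at this place moved the number little. With nothing pointing in either direction, a step within the scatter seems the most reasonable expectation, with wide uncertainty.

Compound 4 is therefore estimated at 350 nM, with a range from 60 nM to 2000 nM. For compound 4 the expected step is a 1.4-fold lower number from compound 3 to compound 4 (0.14 log units; within the scatter).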

Compound 4, concentration for 50% growth inhibition: 50 nM
Estimate against measurement, compound 4: 7.0-fold (0.85 log units) above; measured number below the stated range.
By their numbers in this assay, from the lowest: compound 4; then compounds 2 and 3 (each within the scatter of the next). At a limit, below all of these: compound 1.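

In this assay, hydroxy in place of chloro on the aromatic carbon ortho to a methoxy group gives a 9.6-fold lower number from compound 3 to compound 4 (0.98 log units; beyond the scatter) and is a modest step beyond the scatter, so this position is not indifferent to the group it carries. Hydroxy in place of hydrogen at the same place gives a 6.6-fold lower number from compound 2 to compound 4 (0.82 log units; beyond the scatter) and also lies beyond the scatter, whereas chloro in place of hydrogen gave a 1.5-fold higher number from compound 2 to compound 3 (0.16 log units; within the scatter) and stayed within it, so the earlier impression that a small group changes little here holds for chloro but not for hydroxy. Hydroxy brings one hydrogen-bond donor and one hydrogen-bond acceptor by count where chloro brings none, but nothing at hand explains why the number falls with hydroxy.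

On these data alone, whether the fall belongs to hydroxy alone stays open, since an amine, a carboxylic acid or a longer chain on that oxygen at the same place could each give a different number. Compound 1 gives < 0.1 nM as a limit of the assay and not a number, and it differs from the others in more than one place, so it adds nothing about this position.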